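From a Fluorophenyl to a Dichlorophenyl in Growth Inhibition

The compounds below may be only part of what the source reports. "The series", "measured", "known", "first", "only" and "open" are said of these compounds alone.

Compound 1, `Cc1ccsc1/C=C(/SCc1ccc(Cl)cc1)C(=O)c1ccc(Cl)cc1`, in a functional assay on DU-145 cells (Homo sapiens) for inhibition, read by trypan blue exclusion, with a stated time of 96 h; a lower number here means a stronger inhibitor of growth, a higher number a weaker inhibitor of growth: 50000 nM
Compound 2, `COc1cc(/C=C(/SCc2ccc(Br)cc2)C(=O)c2ccc(Br)cc2)cc([N+](=O)[O-])c1O`, in this assay: 25000 nM
Compound 3, `Cc1ccc(CS/C(=C/c2ccccc2F)C(=O)c2ccc(Cl)cc2)cc1`, in this assay: 10000 nM

Compound 3 gives the lowest number of the three. Compound 2 stands nearest to it, with a gap beyond the usual scatter, and compound 1 stands furthest, also beyond the scatter. Compound 4, `Cc1ccc(CS/C(=C/c2cccc(Cl)c2Cl)C(=O)c2ccc(Cl)cc2)cc1`, has not been measured in this assay. It differs from compound 3 in one place: 2,3-dichlorophenyl in place of 2-fluorophenyl on a double-bonded chain carbon bound to a double-bonded chain carbon. Among the compounds with values here, no measured pair shows this change, so its effect is unknown. The step is expected to be small, no further than the scatter of the method, though a slightly lower number is thought somewhat more likely; the expected step is a 1.4-fold lower number from compound 3 to compound 4 (0.15 log units; within the scatter). Compound 4 is therefore estimated at 7000 nM, in the range 2500 nM to 20000 nM.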

Compound 4, concentration for 50% growth inhibition: 25000 nM
The estimate for compound 4 lay 3.6-fold (0.55 log units) below the measured number, outside the stated range (above it).
By their numbers in this assay, from the lowest: compound 3; then compounds 2, 4 and 1 (each within the scatter of the next).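

In this assay, within the data shown here, the one comparison in which a single place changes gives a 2.5-fold higher number from compound 3 to compound 4 (0.40 log units; beyond the scatter), a step beyond the scatter. This place on a double-bonded chain carbon bound to a double-bonded chain carbon is therefore not indifferent to its group, and 2,3-dichlorophenyl does worse here than 2-fluorophenyl. Nothing available explains this step.

The change removes the fluorine and brings in two chlorines at once, so these compounds cannot separate those parts. From the compounds shown here alone, how an amine or a carboxylic acid on this phenyl would behave remains open.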